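The source may hold more compounds than are shown below. What is called first, only, known or untested is meant among the compounds shown, and "the series" means these compounds.

In a functional assay on HCT-116 cells (Homo sapiens) for inhibition, read by MTT assay, with a stated time of 48 h (a higher number here means a weaker inhibitor, a lower number a stronger inhibitor), compound 1 `COc1cc(-c2nnc(SCc3ccc(C)cc3)n2-c2ccc(N(C)C)cc2)cc(OC)c1OC` is reported only as a limit, > 60000 nM. Compound 2 `COc1cc(-c2nnc(SCC(=O)c3ccccc3)n2-c2ccc(N(C)C)cc2)cc(OC)c1OC` gives 42500 nM, and compound 3 `COc1cc(-c2nnc(SCC(=O)c3ccc4ccccc4c3)n2-c2ccc(N(C)C)cc2)cc(OC)c1OC` gives 54500 nM. These two values lie within the scatter of each other, so compound 3 stands level with compound 2 in this small set.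

Compound 4 `COc1ccc(NC(=O)CSc2nnc(-c3cc(OC)c(OC)c(OC)c3)n2-c2ccc(N(C)C)cc2)cc1` has not yet been measured. It keeps the shared core and the carbonyl on the sulfur chain, but the group on that carbonyl changes: (4-methoxyphenyl)amino in place of naphthalen-2-yl on a carbonyl carbon. In words, this is (4-methoxyphenyl)amino in place of naphthalen-2-yl on a carbonyl carbon, which turns (naphthalen-2-yl)carbonyl into (4-methoxyphenyl)carbamoyl.

The closest guide is the earlier change at the same carbonyl carbon, a 1.3-fold higher number from compound 2 to compound 3 (0.11 log units; within the scatter). Two broader exchanges on the sulfur chain, an at least 1.4-fold lower number from compound 1 to compound 2 (0.14 log units; that floor lies within the scatter) and an at least 1.1-fold lower number from compound 1 to compound 3 (0.04 log units; that floor lies within the scatter), also give only floors that stay within the scatter. None of these steps tests a carbamoyl group, so the guidance is loose.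

On this evidence, no step beyond the scatter is expected in this assay, with only a slight lean towards a lower number. The estimated step is a 1.8-fold lower number from compound 3 to compound 4 (0.26 log units; within the scatter). Compound 4 is expected at 30000 nM, with an estimated range of 10000 nM to 60000 nM.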

Compound 4, half-maximal inhibitory concentration: > 60000 nM
Compound 4 ended at the assay's limit; the forecaster's own chance of this, stated with the estimate: 20%; middle value at least 2.0-fold (0.30 log units) from the limit.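

Placing (4-methoxyphenyl)amino on the carbonyl carbon brings no gain in this assay over either earlier carbonyl compound, with one comparison reading (an at least 1.1-fold higher number from compound 3 to compound 4 (0.04 log units; that floor lies within the scatter)) and the other (an at least 1.4-fold higher number from compound 2 to compound 4 (0.14 log units; that floor lies within the scatter)). Both are floors within the scatter, which leaves the true size of each step unknown, and the step linking compound 1 to compound 4 cannot be read. Across phenyl, naphthalen-2-yl and (4-methoxyphenyl)amino, this carbonyl carbon has given no step shown to lie beyond the scatter, and compound 4 now ends at the same limit as compound 1: the limit of > 60000 nM in this assay, at which 2 of the 4 values shown sit.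

As far as these compounds go, it remains open whether the methoxy group or the amide nitrogen counts for more here, and a plain phenylamino group on the same carbonyl carbon would separate the two. Also open, from the compounds shown here alone, is how this carbonyl carbon responds to a group without an aromatic ring, such as dimethylamino or a longer chain ending in a carboxylic acid.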